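Benzyl Variation on a Rhodanine-Acetic Acid Benzimidazole Series

The source may report more compounds than this note shows. Statements on the series, on what has been measured and on what is new or still open speak of the compounds shown alone.

Measured so far:
compound 1 `O=C(O)CN1C(=O)/C(=C/c2nc3ccccc3n2Cc2ccc(Br)cc2)SC1=S` — 1190 nM
compound 2 `Cc1ccc(Cn2c(/C=C3\SC(=S)N(CC(=O)O)C3=O)nc3ccccc32)cc1` — 960 nM
compound 3 `O=C(O)CN1C(=O)/C(=C/c2nc3ccccc3n2Cc2ccc(F)cc2F)SC1=S` — 8960 nM

Three members of the series have been read in a functional assay on Raji cells (Homo sapiens) for cytotoxicity, read by MTT assay, with a stated time of 48 h; on this read-out lower numbers stand for stronger inhibition and higher numbers for weaker inhibition. Compound 1 holds the second highest of the three numbers; compound 2 sits nearest, with a 1.2-fold lower number from compound 1 to compound 2 (0.09 log units; within the scatter), a change that falls inside the usual scatter. Compound 3 is the furthest away, with a 7.5-fold higher number from compound 1 to compound 3 (0.88 log units; beyond the scatter), and the same direction is seen with a 9.3-fold higher number from compound 2 to compound 3 (0.97 log units; beyond the scatter).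

The next compound, compound 4 `O=C(O)CN1C(=O)/C(=C/c2nc3ccccc3n2Cc2cccc(F)c2)SC1=S`, is not yet measured. Against compound 1 the change is 3-fluorophenyl in place of 4-bromophenyl on a saturated chain carbon bound to an aromatic nitrogen.

Within the data shown here, two measured steps bear on this change. The replacement of bromo by methyl on the aromatic carbon gave a 1.2-fold lower number from compound 1 to compound 2 (0.09 log units; within the scatter), which says nothing beyond noise. The move to a fluorinated benzyl gave a 7.5-fold higher number from compound 1 to compound 3 (0.88 log units; beyond the scatter), a modest loss. The 3-fluorophenyl of compound 4 is a fluorinated benzyl as well, though not the same group as in compound 3, so the step is expected to lie between those two outcomes.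

For compound 4 in this assay the expected value is 3000 nM, with a range from 1200 nM to 8000 nM. Among the measured compounds shown here, this estimate amounts to a step of a 2.5-fold higher number from compound 1 to compound 4 (0.40 log units; beyond the scatter), a rise expected to be smaller than the one seen for compound 3.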

Compound 4, half-maximal inhibitory concentration: 13300 nM
Estimate against measurement, compound 4: 4.4-fold (0.65 log units) below; measured number above the stated range.
By their numbers in this assay, from the lowest: compounds 2 and 1 (each within the scatter of the next); then compounds 3 and 4 (each within the scatter of the next).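

In this assay the change from 4-bromobenzyl to 3-fluorobenzyl gives an 11-fold higher number from compound 1 to compound 4 (1.05 log units; beyond the scatter) and is a large step, and the swap of 4-methylphenyl for 3-fluorophenyl on the same saturated chain carbon gives a 14-fold higher number from compound 2 to compound 4 (1.14 log units; beyond the scatter) as a second large step. The loss seen earlier with 2,4-difluorophenyl is therefore not confined to that one group: a 3-fluorophenyl with its single fluorine cannot be told apart from it, with a 1.5-fold higher number from compound 3 to compound 4 (0.17 log units; within the scatter) as the step between them. Across these four compounds the benzyl groups now fall into two sets, compounds 1 and 2 together and the fluorinated compounds 3 and 4 together, with no compound going against that split, and nothing shown gives a reason for it.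

The compounds shown leave open whether the split follows the presence of fluorine or the loss of a bromo or methyl group from the 4-position of the phenyl, which an unsubstituted benzyl, a 4-chlorobenzyl or a 4-methoxybenzyl would help to separate. Also open, on these data alone, is how far the split holds when the carboxylic acid shared by all four gives way to an ester or an amide.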